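This account rests on a few compounds, and the source may have more. Where it says the series, first, only, none or still open, it means among the compounds named here.

Of the compounds shown here, three built on one shared core have been measured in an assay on HEK293 cells for inhibition of Steryl-sulfatase (Homo sapiens), tested at 1 uM; on this read-out lower numbers stand for a weaker effect and higher numbers for a stronger effect at the one concentration tested. Compound 1 `NS(=O)(=O)Oc1ccc2c(c1)CN(C(=O)c1cccc(N3CCC(Cc4ccccc4)CC3)c1)CC2` gives 41.9%. Compound 2 `CCN(Cc1ccc(F)cc1)c1ccc(C(=O)N2CCc3ccc(OS(N)(=O)=O)cc3C2)cc1` gives 91.2%, and compound 3 `NS(=O)(=O)Oc1ccc2c(c1)CN(C(=O)c1cccc(N(Cc3ccccc3)Cc3ccco3)c1)CC2` gives 90.5%. For the measured compounds named here, compound 1 therefore stands lowest of the three; its nearest neighbour is compound 3, and both gaps, the one to compound 3 and the one to compound 2, lie beyond the scatter of repeated measurements.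

The unmeasured compound 4 `NS(=O)(=O)Oc1ccc2c(c1)CN(C(=O)c1cccc(N3CCCCC3)c1)CC2` differs from compound 1 in a single place: hydrogen in place of benzyl on a saturated ring carbon. Going by the values given here, no pair of measured compounds differs by this change alone, so nothing measured shows its effect directly. What remains in compound 4 is the six-membered non-aromatic ring with one nitrogen, bearing no further group. Compound 1 already sits low, and a modest decrease, or none beyond the scatter, is expected: a number 8.9 percentage points lower from compound 1 to compound 4 (within the scatter). Compound 4 is thus estimated to give 33% in this assay, within a range from 12% to 58%.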

Compound 4, a percentage reported as inhibition, at one concentration (the size of the read-out at that concentration, not a potency): 11.9%
Compound 4: the middle estimate sits 21.1 percentage points above what was measured, and the stated range ends above it.
By their numbers in this assay, from the lowest: compound 4; then compound 1; then compounds 3 and 2 (each within the scatter of the next).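

Replacing the benzyl with hydrogen on this saturated ring carbon, three ring bonds from the ring nitrogen, gives a number 30 percentage points lower from compound 1 to compound 4 (beyond the scatter) in this assay. For the compounds shown here, compound 1 was already the lowest of the earlier compounds, yet the group at this position can still be removed at a measurable cost, so the number had not reached a floor that hides further loss. No measurement shown explains why the number falls.

The compounds shown leave open whether the loss depends on the aromatic ring of the benzyl or on having any group at this carbon, which a methyl or a cyclohexylmethyl group there could help separate. Going by these compounds, it also remains open how a phenyl attached directly to this carbon, or a longer chain ending in phenyl, would compare with benzyl.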